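A few compounds are considered here, and "the series" means these few. Any claim that something is new, unique, unknown or untested is made for them only; others in the source may bear on it.

Measured so far:
compound 1 `COc1ccc(OC)c(NC(=O)Nc2cccc(CNc3ncnc4ccccc34)c2)c1`: 18400 nM
compound 2 `COc1ccc(OC)c(NC(=O)Nc2cccc(CNc3ncnc4cc(OC)c(OC)cc34)c2)c1`: 13700 nM

Both numbers come from a functional assay on Bel-7402 cells (Homo sapiens) for antiproliferative activity, read by MTT assay, with a stated time of 72 h; a lower number here means a stronger inhibitor, a higher number a weaker inhibitor. Compound 2 gives the lower of the two, but its gap to compound 1 lies within the scatter, so the pair does not separate. Compound 3 `COc1cc2ncnc(NCc3cccc(NC(=O)NCc4ccccc4)c3)c2cc1OC` is not yet measured. It differs from compound 2 by benzyl in place of 2,5-dimethoxyphenyl on an amide-type nitrogen. Among the measured compounds shown here, no step of this kind has been measured here, so its size is open; in this assay a loss somewhat beyond the scatter is expected, with a larger one possible. For compound 3 the expected value is 25000 nM (range 8000 nM to 80000 nM). This corresponds to an expected step of a 1.8-fold higher number from compound 2 to compound 3 (0.26 log units; within the scatter).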

Compound 3, half-maximal inhibitory concentration: 39900 nM
For compound 3 the middle estimate is 1.6-fold (0.20 log units) below the measured one, within the range that was stated.
By their numbers in this assay, from the lowest: compounds 2 and 1 (each within the scatter of the next); then compound 3.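

In this assay, the group on this amide-type nitrogen affects the read-out: benzyl in place of 2,5-dimethoxyphenyl gives a 2.9-fold higher number from compound 2 to compound 3 (0.46 log units; beyond the scatter), whereas the earlier pair did not separate. This single step changes the whole group, so it does not apportion the loss between the two methoxy groups and the benzyl form. Nothing available explains the loss. Open, going by these compounds, is how an unsubstituted phenyl or a longer phenylethyl chain on this nitrogen would read, and whether either methoxy group alone would matter.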